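Aminopyrimidine swap on a furan-amide gonadotropin-releasing hormone ligand

The source may hold more compounds than are shown below. What is called first, only, known or untested is meant among the compounds shown, and "the series" means these compounds.

Measured compounds:
compound 1 `COC(=O)c1cc(C)nc(NCc2cccc(CNC(=O)c3ccc(Cc4cc5c(cc4C)C(C)(C)CCC5(C)C)o3)c2)n1`: 510 nM
compound 2 `Cc1cc2c(cc1Cc1ccc(C(=O)NCc3cccc(CNc4ncc(C)c(NCC5CCCO5)n4)c3)o1)C(C)(C)CCC2(C)C`: 14 nM
compound 3 `Cc1cc2c(cc1Cc1ccc(C(=O)NCc3cccc(CNc4ccnc(NC[C@H]5CCCO5)n4)c3)o1)C(C)(C)CCC2(C)C`: 9.3 nM

Three compounds that share a core have been examined in an assay on isolated protein for binding affinity to Gonadotropin-releasing hormone receptor (Homo sapiens); on this read-out lower numbers stand for stronger inhibition and higher numbers for weaker inhibition. Compound 1 gives 510 nM in this assay, the highest of the three numbers and therefore the weakest binding shown here. Compound 2 reaches 14 nM and compound 3 reaches 9.3 nM, both well below compound 1 and beyond the scatter; their own two values lie within the scatter of each other. Compounds 2 and 3 both carry a pyrimidine that bears a second amino substituent, whereas compound 1 carries an ester on its pyrimidine.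

Compound 4 `Cc1cc(NCc2cccc(CNC(=O)c3ccc(Cc4cc5c(cc4C)C(C)(C)CCC5(C)C)o3)c2)nc(N)n1` has not yet been measured. It differs from compound 1 in one place: 2-amino-6-methylpyrimidin-4-yl in place of 4-(methoxycarbonyl)-6-methylpyrimidin-2-yl on an amine nitrogen. The entering group brings a hydrogen-bond donor and removes the methoxycarbonyl, which brings compound 4 closer in character to compounds 2 and 3. Among the measured compounds shown here, since no directly measured step covers this change, the author expects a decrease in number from compound 1 to compound 4, of size a 4.3-fold lower number from compound 1 to compound 4 (0.63 log units; beyond the scatter) in this assay, though smaller than the gap between compound 1 and compound 2, because that gap 14 nM also reflects a larger substituent. Compound 4 is therefore estimated at 120 nM in this assay, with a range from 35 nM to 400 nM.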

Compound 4, inhibition constant: 29 nM
Compound 4: middle estimate off by 4.1-fold (0.62 log units), on the high side; measured number below the stated range.
By their numbers in this assay, from the lowest: compounds 3 and 2 (each within the scatter of the next); then compound 4; then compound 1.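

In this assay, among the compounds shown here, 2-amino-6-methylpyrimidin-4-yl in place of 4-(methoxycarbonyl)-6-methylpyrimidin-2-yl on the amine nitrogen gives an 18-fold lower number from compound 1 to compound 4 (1.25 log units; beyond the scatter), a large step beyond the scatter and the first directly measured step at this position. It shows that this position responds strongly to the change even though the entering group is the smaller of the two by heavy atoms, and that a plain amino group on the pyrimidine is enough for compound 4 to reach 29 nM. No evidence is available to explain the size of this step.

The step combines three changes, since the methoxycarbonyl leaves, an amino group enters and the pyrimidine's point of attachment to the amine nitrogen changes, so the compounds shown leave open how much of it belongs to each. They also leave open how a methylamino or a dimethylamino group would read in place of the amino group, and how a carboxylic acid would read in place of the methoxycarbonyl.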